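A few compounds are considered here, and "the series" means these few. Any claim that something is new, unique, unknown or untested is made for them only; others in the source may bear on it.

Compound 2 `COc1ccc(/C=N/Nc2ncc3c(n2)n(C2CCCC2)c(=O)c(=O)n3C)cc1` carries a 4-methoxyphenyl group. In a functional assay on A549 cells (Homo sapiens) for antiproliferative activity, read by MTT assay (a lower number here means a stronger inhibitor, a higher number a weaker inhibitor), compound 2 gives > 100000 nM, which is a limit of the assay rather than a number. Compound 1 `COc1ccc(/C=N/Nc2ncc3c(n2)n(C2CCCC2)c(=O)c(=O)n3C)c(OC)c1` differs from it by one methoxy group. In this assay compound 1 gives > 100000 nM, again a limit. The step that the two limits leave unreadable from compound 1 to compound 2 cannot be read because of the limit of > 100000 nM in this assay, at which 2 of the 2 values shown sit. Compound 3 `Cn1c(=O)c(=O)n(C2CCCC2)c2nc(N/N=C/c3cccc([N+](=O)[O-])c3)ncc21` changes (3-nitrophenyl in place of 4-methoxyphenyl on a carbon with a double bond to nitrogen). No readable step bears on this change, so the estimated step of a number no higher from compound 2 to compound 3 (the limit leaves the size open) is set at nothing beyond the scatter. Compound 3 is expected at 100000 nM, in the range 20000 nM to 500000 nM.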

Compound 3, half-maximal inhibitory concentration: 12300 nM
Compound 3: middle estimate off by 8.1-fold (0.91 log units), on the high side; the whole stated range lies above it.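

In this assay, 3-nitrophenyl on a carbon with a double bond to nitrogen brings an at least 8.1-fold lower number from compound 2 to compound 3 (0.91 log units; beyond the scatter), and in place of 2,4-dimethoxyphenyl it brings an at least 8.1-fold lower number from compound 1 to compound 3 (0.91 log units; beyond the scatter). The group at this position can therefore move the result, which the two methoxy compounds, both at a limit of the assay, could not show. The full size of both steps stays open because their starting points are limits: the limit of > 100000 nM in this assay, at which 2 of the 3 values shown sit.

On these data alone, whether the nitro group itself matters or only the loss of methoxy remains open. A plain phenyl, or a ring carrying an amine or a carboxylic acid, would bear on that.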